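The source may hold more compounds than are shown below. What is called first, only, known or untested is meant among the compounds shown, and "the series" means these compounds.

Measured so far in a functional assay on HT cells (Homo sapiens) for antiproliferative activity, read by fluorescence, with a stated time of 72 h; on this read-out lower numbers stand for stronger inhibition of growth and higher numbers for weaker inhibition of growth:
compound 1, `CC(C)c1n[nH]c2c(NCc3ccc(-c4ccccn4)cc3)nc(SCCC(N)=O)nc12`: 120 nM
compound 2, `CC(C)c1n[nH]c2c(NCc3ccc(-c4ccccn4)cc3)nc(SCCNC(N)=O)nc12`: 240 nM

Among the compounds with values here, compound 2 holds the higher of the two numbers, but its only neighbour is compound 1, and the step of a 2.0-fold higher number from compound 1 to compound 2 (0.30 log units; within the scatter) stays within the scatter, so the two compounds cannot be ordered on this assay.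

Compound 3, `COCSc1nc(NCc2ccc(-c3ccccn3)cc2)c2[nH]nc(C(C)C)c2n1`, is not yet measured. It differs from compound 2 by methoxy in place of ureidomethyl on a saturated chain carbon bound to a sulfur. Within the data shown here, the one measured step, from compound 1 to compound 2, altered the chain end while keeping its length and a hydrogen-bond donor; the change to compound 3 removes both donors and shortens the chain, so that step is only a loose guide. Among the measured compounds shown here, no measured pair shows what removing the chain-end donors does here.

For compound 3 a modest weakening, a 1.7-fold higher number from compound 2 to compound 3 (0.22 log units; within the scatter), is expected, with wide uncertainty. The estimate for compound 3 is 400 nM, range 120 nM to 1500 nM.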

Compound 3, concentration for 50% growth inhibition: 340 nM
For compound 3 the middle estimate is 1.2-fold (0.07 log units) above the measured one; the range from low to high includes it.
By their numbers in this assay, from the lowest: compounds 1, 2 and 3 (each within the scatter of the next, the first and the last beyond it).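

In this assay methoxy in place of ureidomethyl on a saturated chain carbon bound to a sulfur gives a 1.4-fold higher number from compound 2 to compound 3 (0.15 log units; within the scatter) and so leaves compound 2 and compound 3 unordered, although methoxy has 0 hydrogen-bond donors and the group it replaces has 2. Methoxy in place of carbamoylmethyl at the same place gives a 2.8-fold higher number from compound 1 to compound 3 (0.45 log units; beyond the scatter) and is the first step in the series beyond the scatter, though only a modest one, so the chain-end donors of compound 1 and compound 2 are not needed for most of the growth inhibition seen here. Nothing on hand accounts for either step.

Still open, going by these compounds, is whether an amine or a carboxylic acid at the chain end would shift the read-out beyond the scatter. Also open, on these data alone, is how a longer chain carrying the methoxy group, or a plain methyl on the sulfur, would compare with compound 3.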